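Amino in Place of Chloro: Expected Loss of Growth Inhibition

The source may report more compounds than this note shows. Statements on the series, on what has been measured and on what is new or still open speak of the compounds shown alone.

Measured so far: compound 3 `ClCc1ccc(Cn2cnc3c(Cl)nc(Cl)nc32)cc1`, 4570 nM; compound 1 `Nc1nc(Cl)c2ncn(Cc3ccc(CCl)cc3)c2n1`, > 100000 nM; compound 2 `ClCc1cccc(Cn2cnc3c(Cl)nc(Cl)nc32)c1`, > 100000 nM.

In a functional assay on CCRF-CEM cells (Homo sapiens) for cytotoxicity, read by sulforhodamine B assay, with a stated time of 48 h (a higher number here means a weaker inhibitor of growth, a lower number a stronger inhibitor of growth), compound 3 gives 4570 nM. For compound 1 the assay reports only a limit, > 100000 nM. The change from compound 3 to compound 1 is amino in place of chloro on an aromatic carbon, and it brought an at least 21-fold higher number from compound 3 to compound 1 (1.34 log units; beyond the scatter), consistent with the limit of > 100000 nM in this assay, at which 2 of the 3 values shown sit. Compound 2 also sits at a limit, > 100000 nM; the difference between the cores of compound 2 and compound 3 is not broken down here. Compound 4 `Nc1nc(Cl)c2ncn(Cc3cccc(CCl)c3)c2n1` is unmeasured; it differs from compound 2 by amino in place of chloro on an aromatic carbon, the same change as from compound 3 to compound 1. Because compound 2 already gives > 100000 nM, compound 4 is expected to remain at or beyond the limit, an expected step that the limit leaves unreadable from compound 2 to compound 4. The estimate for compound 4 is 200000 nM, expected between 100000 nM and 1000000 nM.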

Compound 4, concentration for total growth inhibition: > 100000 nM
Compound 4 was reported as a limit; the forecaster's own chance of this, stated with the estimate: 90%; the middle value is on the limit's open side.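

No step can be read between compound 2 and compound 4, because both are reported only as limits: the limit of > 100000 nM in this assay, at which 3 of the 4 values shown sit.

The compounds shown leave open whether amino in place of chloro changes growth inhibition at all in the pair of compound 2 and compound 4.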